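A few compounds are considered here, and "the series" means these few. Any claim that something is new, unique, unknown or untested is made for them only; others in the source may bear on it.

Compound 1 `COc1ccccc1Oc1cncc(C2=CC3CNCC(C2)C3)c1` gives 1 nM in an in vitro assay on SH-EP1 cells for displacement of a labelled ligand from Neuronal acetylcholine receptor; alpha4/beta2 (Homo sapiens) (a lower number here means a stronger inhibitor, a higher number a weaker inhibitor), and compound 2 `Fc1ccc(Oc2cncc(C3=CC4CNCC(C3)C4)c2)cc1` gives 0.6 nM in this assay. For the measured compounds named here, the only step with a single change, a 1.7-fold lower number from compound 1 to compound 2 (0.22 log units; within the scatter), is a swap of one aryl group for another on the oxygen. On the numbers seen so far compound 2 stands at the lower of the two values, but its gap to compound 1 is within the scatter, so neither can be called the stronger binder.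

Compound 3 `CC(C)Oc1cncc(C2=CC3CNCC(C2)C3)c1` differs from compound 2 by isopropyl in place of 4-fluorophenyl on an oxygen on an aromatic ring. Going by the values given here, no measured step replaces an aryl group on that oxygen with an alkyl group, so the one measured step bears on it only as a sign that the group on the oxygen was tolerant to an aryl-for-aryl exchange. For compound 3 the expected outcome in this assay is 3 nM, with a range of 0.5 nM to 20 nM, which would mean an expected step of a 5.0-fold higher number from compound 2 to compound 3 (0.70 log units; beyond the scatter) from compound 2 to compound 3.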

Compound 3, inhibition constant: 0.26 nM
Beside the measured number, compound 3's estimate is 12-fold (1.06 log units) above it, and the stated range ends above it.
By their numbers in this assay, from the lowest: compound 3; then compounds 2 and 1 (each within the scatter of the next).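

On the oxygen on an aromatic ring, an alkyl group now replaces an aryl group with no loss in this assay: isopropyl in place of 4-fluorophenyl gives a 2.3-fold lower number from compound 2 to compound 3 (0.36 log units; beyond the scatter), and isopropyl in place of 2-methoxyphenyl gives a 3.8-fold lower number from compound 1 to compound 3 (0.59 log units; beyond the scatter). The tolerance seen earlier at this position is therefore not confined to aryl groups, and among the three compounds shown, a ring on this oxygen is not required for binding at this level. No measurement at hand accounts for these steps.

With isopropyl as the only alkyl group shown, it remains open whether methyl, cyclopropyl or a longer chain would give similar numbers. From the compounds shown here alone, it is also open whether a group carrying an amine or a carboxylic acid would be accepted on this oxygen.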